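Swapping Ethyl for 4-Cyanophenyl on a Shared Core

The compounds below may be only part of what the source reports. "The series", "measured", "known", "first", "only" and "open" are said of these compounds alone.

Measured compounds in an in vitro functional assay on cells for antagonist activity at transient receptor potential cation channel subfamily V member 1 (Homo sapiens), read by FLIPR and calcium flux; a lower number here means a stronger inhibitor, a higher number a weaker inhibitor:
compound 1, `Cc1ccc(-c2cnc(Nc3cccc4c3CC(O)CC4)o2)cc1`, 62 nM
compound 2, `NC1CCc2cccc(Nc3ncc(-c4ccc(C(F)(F)F)cc4)o3)c2C1`, 327 nM
compound 3, `CCc1nc(Nc2cccc3c2CC(O)CC3)oc1-c1ccc(C(F)(F)F)cc1`, 2.1 nM

Among these three, compound 3 gives the lowest number in this assay; compound 1 stands nearest to it and compound 2 furthest, and both gaps lie beyond the scatter. Compound 4, `N#Cc1ccc(-c2nc(Nc3cccc4c3CC(O)CC4)oc2-c2ccc(C(F)(F)F)cc2)cc1`, has not yet been measured. It differs from compound 3 in one place: 4-cyanophenyl in place of ethyl on an aromatic carbon. Among the measured compounds shown here, no pair of measured compounds differs in a single spot, so nothing measured so far isolates the effect of a change at this position. The step of a 2.9-fold higher number from compound 3 to compound 4 (0.46 log units; beyond the scatter) is expected to be a modest loss, well short of the gap between compound 3 and compound 1. Compound 4 is therefore estimated at 6 nM, with a range from 1.5 nM to 30 nM.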

Compound 4, half-maximal inhibitory concentration: 2 nM
The estimate for compound 4 lay 3.0-fold (0.48 log units) above the measured number; the range from low to high includes it.
By their numbers in this assay, from the lowest: compounds 4 and 3 (each within the scatter of the next); then compound 1; then compound 2.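

In this assay, among the compounds shown here, 4-cyanophenyl in place of ethyl gives a 1.1-fold lower number from compound 3 to compound 4 (0.02 log units; within the scatter), the first comparison that isolates this position. This aromatic carbon, next to the ring nitrogen, thus carries either ethyl, with 2 heavy atoms, or 4-cyanophenyl, with 8 heavy atoms and an aromatic ring, with no shift beyond the scatter. Nothing available gives a reason for this outcome. From the compounds shown here alone, it remains open whether a plain phenyl, an amine or a carboxylic acid at this carbon would fit the same picture. The part played by the nitrile also remains unresolved.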